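The source may hold more compounds than are shown below. What is called first, only, known or untested is meant among the compounds shown, and "the series" means these compounds.

Measured compounds:
compound 1 `CC(=O)Oc1ccccc1C1CC(C)=NN1C(=O)CN1CCC(O)CC1`: 25600 nM
compound 2 `CC[N+](C)(CC)CC(=O)N1N=C(C)CC1c1ccccc1OC`: 4170 nM
compound 3 `CCNCC(=O)N1N=C(c2cc3ccccc3oc2=O)CC1c1ccccc1`: 5580 nM

In a functional assay on PC-3 cells (Homo sapiens) for cytotoxicity, read by MTT assay, with a stated time of 48 h (a higher number here means a weaker inhibitor, a lower number a stronger inhibitor), compound 1 gives 25600 nM, compound 2 gives 4170 nM and compound 3 gives 5580 nM. Compound 3 stands with a number close to that of compound 2, a gap that falls within the scatter of this assay, and well apart from compound 1, whose higher number lies beyond the scatter. Compound 4 `CN1CCN(CC(=O)N2N=C(c3cc4ccccc4oc3=O)CC2c2ccccc2)CC1` has not yet been measured; it differs from compound 3 in one place: 4-methylpiperazin-1-yl in place of ethylamino on a saturated chain carbon bound to a carbonyl carbon. For the measured compounds named here, no step between two measured compounds has been recorded for this kind of change, so nothing directly anchors its size. The three measured numbers span only a narrow band, and compound 2, which also carries a larger amine on the chain carbon bound to the carbonyl carbon, gives 4170 nM, not far from compound 3. The step from compound 3 to compound 4 in this assay is therefore expected to be small, a 1.4-fold lower number from compound 3 to compound 4 (0.14 log units; within the scatter), with no clear direction beyond the scatter. Compound 4 is expected to give about 4000 nM, within a range from 1500 nM to 12000 nM.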

Compound 4, half-maximal inhibitory concentration: 25800 nM
Beside the measured number, compound 4's estimate is 6.5-fold (0.81 log units) below it, outside the stated range (above it).
By their numbers in this assay, from the lowest: compounds 2 and 3 (each within the scatter of the next); then compounds 1 and 4 (each within the scatter of the next).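

In this assay the change of 4-methylpiperazin-1-yl in place of ethylamino, on a saturated chain carbon bound to a carbonyl carbon, gives a 4.6-fold higher number from compound 3 to compound 4 (0.66 log units; beyond the scatter) and this step lies beyond the scatter. For the compounds shown here, it is the first step recorded at this place, and it shows that with the rest of the molecule held the same, the group on this chain carbon can shift the number measurably, here towards weaker inhibition. Nothing measured here accounts for the rise.

On these data alone, whether a morpholine or a dimethylamino group at this place would stay with the higher number or return to the lower one remains open. The compounds shown also leave open whether the step holds on another core, since compound 1 and compound 2 differ from compound 3 in more than one place.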